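The source may hold more compounds than are shown below. What is called first, only, known or untested is meant among the compounds shown, and "the series" means these compounds.

Of the compounds shown here, two built on the same core have been measured so far, and they differ only in how the phenyl is attached to the anilide ring. Compound 1 `O=C(CCc1cccc2c1B(O)OC2)Nc1cccc(-c2ccccc2)c1` stands lowest of the two numbers in a functional assay on HCT-116 cells (Homo sapiens) for antiproliferative activity, read by MTT assay, with a stated time of 72 h; a lower number here means a stronger inhibitor, a higher number a weaker inhibitor: compound 1 gives 890 nM. Its isomer compound 2 `O=C(CCc1cccc2c1B(O)OC2)Nc1ccc(-c2ccccc2)cc1` gives 13000 nM in this assay, a difference beyond the scatter, so the arrangement found in compound 1 is the one to build on.

Compound 3 `O=C(CCc1cccc2c1B(O)OC2)Nc1cccc(-c2ccc(C(F)(F)F)cc2)c1` keeps that arrangement and alters the distal ring alone: trifluoromethyl in place of hydrogen on an aromatic carbon. Read one bond further out, the change is phenyl to 4-(trifluoromethyl)phenyl, the new group sitting para to a large group. Among the measured compounds shown here, no measured pair shows this change, so the data give no step to lean on; the only firm point is the value of compound 1. The expectation is therefore a small step from compound 1 to compound 3, a 1.5-fold lower number from compound 1 to compound 3 (0.17 log units; within the scatter), not clearly beyond the scatter, with a slight lean toward a lower number. Compound 3 is estimated at 600 nM, with a range from 200 nM to 2500 nM.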

Compound 3, half-maximal inhibitory concentration: 550 nM
The estimate for compound 3 lay 1.1-fold (0.04 log units) above the measured number, within the range that was stated.
By their numbers in this assay, from the lowest: compounds 3 and 1 (each within the scatter of the next); then compound 2.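

Among the compounds shown here, the distal ring of compound 1 had carried no substituent until now, so compound 3 is the first reading of this position, on an aromatic carbon para to a large group. In this assay, trifluoromethyl in place of hydrogen there gives a 1.6-fold lower number from compound 1 to compound 3 (0.21 log units; within the scatter), which leaves compound 3 and compound 1 level and shows that this position can carry a group of four heavy atoms with the number staying within the scatter of compound 1. The earlier pair spoke only to how the phenyl is attached to the anilide ring, and nothing available here accounts for the flat result at this new position.

As far as these compounds go, it remains open whether another group at this position, such as an amine, a carboxylic acid or a methoxy group, would move the number beyond the scatter, and whether the same position would respond differently to a group placed elsewhere on the distal ring. Also unsettled is how a longer chain joining the shared core to the amide would read in this assay.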